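A few compounds are considered here, and "the series" means these few. Any claim that something is new, unique, unknown or untested is made for them only; others in the source may bear on it.

Measured compounds in an assay on CHO-K1 cells for binding affinity to muscarinic acetylcholine receptor M5 (Homo sapiens); on this read-out higher numbers stand for weaker inhibition and lower numbers for stronger inhibition:
- compound 1, `CC(C1=C(CCN2CCCC2)Cc2ccccc21)c1ccccn1`: 2000 nM
- compound 2, `CCN(CC)CCC1=C(C(C)c2ccccn2)c2ccccc2C1`: 2090 nM
- compound 3, `CC(C1=C(CCN(C(C)C)C(C)C)Cc2ccccc21)c1ccccn1`: 2190 nM; 5130 nM; 11700 nM (3 entries)

Compound 2 and compound 1 are within the scatter of each other, as the step of a 1.0-fold higher number from compound 1 to compound 2 (0.02 log units; within the scatter) shows: swapping one amine for another on the side chain left the number essentially unchanged. Compound 3 carries a third amine at the same place and is recorded with several entries, (the several entries of compound 3 in this assay, 2190 nM; 5130 nM; 11700 nM (3 entries)), all of them at or beyond the other two. Compound 4, `CC(C1=C(CCN(C)C(C)C)Cc2ccccc21)c1ccccn1`, has not yet been measured; it differs from compound 2 by isopropyl(methyl)amino in place of diethylamino on a saturated chain carbon, two bonds along the chain from a double-bonded ring carbon. Among the measured compounds shown here, since the one measured step of this kind, from compound 1 to compound 2, stayed within the scatter, the step of a 1.2-fold higher number from compound 2 to compound 4 (0.08 log units; within the scatter) is expected to be small as well. Compound 4 is therefore estimated at 2500 nM, between 1000 nM and 7000 nM.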

Compound 4, inhibition constant: 2190 nM
Compound 4: the middle estimate sits 1.1-fold (0.06 log units) above what was measured, and the stated range covers the measured number.
By their numbers in this assay, from the lowest: compounds 1, 2 and 4 (each within the scatter of the next).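

In this assay, rearranging the same atoms from diethylamino to isopropyl(methyl)amino gives a 1.0-fold higher number from compound 2 to compound 4 (0.02 log units; within the scatter), and replacing the pyrrolidin-1-yl ring of compound 1 with this open-chain amine gives a 1.1-fold higher number from compound 1 to compound 4 (0.04 log units; within the scatter). Among compounds 1, 2 and 4, the form of the amine at this place on the chain therefore makes no difference beyond the scatter. Compound 3 cannot be placed so simply, as its entries disagree with one another: the several entries of compound 3 in this assay, 2190 nM; 5130 nM; 11700 nM (3 entries)

On these data alone, it remains open whether a morpholine ring at this place, or a longer chain between the amine and the shared core, would shift the number beyond the scatter.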